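The source may hold more compounds than are shown below. What is called first, only, known or untested is meant among the compounds shown, and "the series" means these compounds.

Of the compounds shown here, three have been read in an ADME assay on microsomes from liver (Homo sapiens) for metabolic stability, read by LC-MS, using NADPH, with stated times of 5 min and 30 min, tested at 1 uM (a higher number here means faster removal of the compound, a lower number slower removal), so far. Compound 1 `Cc1ncccc1-c1cnc(NCc2c(F)ccc3c2CCO3)c2nn(CC#N)c(=O)n12` gives 151 mL.min-1.g-1 and compound 2 `O=C1CCCN1c1cnc(NCc2c(F)ccc3c2CCO3)c2cn[nH]c(=O)c12` gives 23 mL.min-1.g-1 as the lower of the two numbers, a gap beyond the scatter. Compound 3 `COCCC(=O)Nc1cnc(NCc2c(F)ccc3c2CCO3)n2cnnc12` returns < 3 mL.min-1.g-1 as a limit, not a number. Compound 4 `CNC(=O)c1cc(-c2cnc(NCc3c(F)ccc4c3CCO4)c3cn[nH]c(=O)c23)n(C)n1` is still unmeasured; it carries 1-methyl-3-(methylcarbamoyl)-1H-pyrazol-5-yl in place of the 2-oxopyrrolidin-1-yl of compound 2 on an aromatic carbon (1-methyl-3-(methylcarbamoyl)-1H-pyrazol-5-yl in place of 2-oxopyrrolidin-1-yl on an aromatic carbon). Among the compounds with values here, no measured pair differs in one place only, so this change has no direct precedent in this assay here. A small upward move within the scatter is expected (a 1.3-fold higher number from compound 2 to compound 4 (0.12 log units; within the scatter)). Compound 4 is estimated at 30 mL.min-1.g-1 with an expected range from 9 mL.min-1.g-1 to 90 mL.min-1.g-1 in this series.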

Compound 4, intrinsic clearance in microsomes: < 3 mL.min-1.g-1
Compound 4 was reported as a limit (the forecaster's own chance of this, stated with the estimate: 10%); at least 10-fold (1.00 log units) between middle value and limit.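

In this assay this position responds to substitution: 1-methyl-3-(methylcarbamoyl)-1H-pyrazol-5-yl in place of 2-oxopyrrolidin-1-yl on the aromatic carbon gives an at least 7.6-fold lower number from compound 2 to compound 4 (0.88 log units; beyond the scatter). Within the data shown here, this is the only single-place step so far. Compound 4 is a limit, not a number, so the step gives only a minimum size: the limit of < 3 mL.min-1.g-1 in this assay, at which 2 of the 4 values shown sit.

Going by these compounds, it remains open whether the five-membered aromatic ring or its methylcarbamoyl carries the step. On these data alone, how a primary amine or a carboxylic acid on this aromatic carbon would read in this assay is also open.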